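Chloro in place of trifluoromethyl: what to expect

The source may hold more compounds than are shown below. What is called first, only, known or untested is meant among the compounds shown, and "the series" means these compounds.

Measured so far in a physicochemical assay for lipophilicity, at pH 7.4 (a higher number here means a more lipophilic compound, a lower number a more polar compound), are these compounds:
Compound 1 `O=C(O)Cn1nc(Cc2nc3cc(Cl)c(OCC(F)F)cc3[nH]2)c2ccccc2c1=O` gives 1.97
Compound 2 `O=C(O)Cn1nc(Cc2nc3cc(C(F)(F)F)c(OCC4CC4)cc3[nH]2)c2ccccc2c1=O` gives 2.79

Compound 2 holds the higher of the two numbers, and its gap to compound 1 lies beyond the scatter of repeated measurements. Compound 3 `O=C(O)Cn1nc(Cc2nc3cc(Cl)c(OCC4CC4)cc3[nH]2)c2ccccc2c1=O` differs from compound 2 in one place, with chloro in place of trifluoromethyl on an aromatic carbon. For the measured compounds named here, no measured pair isolates this change, so the data offer no direct guide. A modest fall in this assay is expected, an estimated a number 0.29 log units lower from compound 2 to compound 3 (within the scatter), and it may prove hard to separate from the scatter. The estimate for compound 3 is 2.5 (range 2.15 to 2.85).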

Compound 3, distribution coefficient: 2.21
The estimate for compound 3 lay 0.29 log units above the measured number; the measured number falls inside the stated range.
By their numbers in this assay, from the lowest: compounds 1 and 3 (each within the scatter of the next); then compound 2.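

In this assay, for the compounds shown here, chloro in place of trifluoromethyl on this aromatic carbon gives a number 0.58 log units lower from compound 2 to compound 3 (beyond the scatter) and so offers the first reading of this change with the rest of the molecule held the same. With chloro kept in place, cyclopropyl in place of difluoromethyl on the saturated chain carbon gives a number 0.24 log units higher from compound 1 to compound 3 (within the scatter) and so cannot be told apart from repeat scatter. No measurement at hand gives a reason for either step.

As far as these compounds go, whether the chloro step holds when the chain ends in difluoromethyl stays open. How a nitrile or a methyl group on this aromatic carbon would read in this assay is open too.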